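From Methyl to Furan-3-yl on the Aromatic Nitrogen

The source may report more compounds than this note shows. Statements on the series, on what has been measured and on what is new or still open speak of the compounds shown alone.

Compound 1 `CCOC(=O)c1ccc(-c2nn(C)c3ccccc23)cc1` gives 270 nM in a functional assay on cells (Platelet, Homo sapiens) for inhibition (on this read-out higher numbers stand for weaker inhibition and lower numbers for stronger inhibition), the lowest of the three numbers measured. Compound 2 `CCOC(=O)c1ccc(-c2nn(Cc3ccccc3OC)c3ccccc23)cc1` gives 470 nM and compound 3 `CCOC(=O)c1ccc(-c2nn(Cc3ccc(OC)cc3)c3ccccc23)cc1` gives 620 nM, so that a 1.7-fold higher number from compound 1 to compound 2 (0.24 log units; within the scatter) while a 2.3-fold higher number from compound 1 to compound 3 (0.36 log units; beyond the scatter). Compound 4 `CCOC(=O)c1ccc(-c2nn(-c3ccoc3)c3ccccc23)cc1` differs from compound 1 by furan-3-yl in place of methyl on an aromatic nitrogen. Among the measured compounds shown here, both measured steps enlarge what hangs from the aromatic nitrogen and both move the number upward, one within the scatter and one modestly beyond it; a group placed directly on the aromatic nitrogen is tested by no measured pair. A small rise or none beyond the scatter is therefore expected, a 1.6-fold higher number from compound 1 to compound 4 (0.19 log units; within the scatter). Compound 4 is estimated at 420 nM, with a range from 150 nM to 1200 nM.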

Compound 4, half-maximal inhibitory concentration: 580 nM
Estimate against measurement, compound 4: 1.4-fold (0.14 log units) below; the range from low to high includes it.
By their numbers in this assay, from the lowest: compounds 1, 2, 4 and 3 (each within the scatter of the next, the first and the last beyond it).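

Furan-3-yl set directly on the aromatic nitrogen, a case the earlier compounds did not cover, gives in this assay a 2.1-fold higher number from compound 1 to compound 4 (0.33 log units; beyond the scatter). Against the two methoxybenzyl compounds it stays level, with a 1.1-fold lower number from compound 3 to compound 4 (0.03 log units; within the scatter) and a 1.2-fold higher number from compound 2 to compound 4 (0.09 log units; within the scatter), so among the compounds shown, a ring bound directly to this nitrogen and a ring held one carbon away are not told apart. The data offer no explanation for these numbers.

From the compounds shown here alone, it remains open how hydrogen, an ethyl group or a chain ending in an amine would read on this nitrogen. Going by these compounds, it is also open whether a carboxylic acid in place of the ethyl ester would change the picture.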